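From a Butyl Chain to a Fluorinated Ring

The compounds below may be only part of what the source reports. "The series", "measured", "known", "first", "only" and "open" are said of these compounds alone.

Of the compounds shown here, three sharing one core have been measured in an ADME assay on HEK293 cells (Homo sapiens) for cytotoxicity, read by sulforhodamine B assay, with a stated time of 48 h, tested at 10 uM; on this read-out higher numbers stand for more inhibition at the one concentration tested (going by the name of the read-out) and lower numbers for less inhibition. Compound 1 `COc1nc2ccc(Br)cc2cc1C(c1ccccc1)n1cc(-c2ccc(Br)cc2)nn1` gives 6.28%. Compound 2 `CCCCCCCc1cn(C(c2ccccc2)c2cc3cc(Br)ccc3nc2OC)nn1` gives 0.17%, and compound 3 `CCCCc1cn(C(c2ccccc2)c2cc3cc(Br)ccc3nc2OC)nn1` gives -3.47%, which stands lowest of the three numbers, although every gap lies within the scatter: a number 6.1 percentage points lower from compound 1 to compound 2 (within the scatter), a number 9.8 percentage points lower from compound 1 to compound 3 (within the scatter) and a number 3.6 percentage points lower from compound 2 to compound 3 (within the scatter). Compound 4 `COc1nc2ccc(Br)cc2cc1C(c1ccccc1)n1cc(-c2ccccc2F)nn1` differs from compound 3 in one place: 2-fluorophenyl in place of butyl on an aromatic carbon. For the measured compounds named here, one measured step bears on this, in the opposite direction, where a butyl replaced a 4-bromophenyl: a number 9.8 percentage points lower from compound 1 to compound 3 (within the scatter), within the scatter. Putting an aromatic ring back in place of the butyl is therefore expected to move the number only slightly, a number 7.5 percentage points higher from compound 3 to compound 4 (within the scatter). Compound 4 is estimated at 4%, with a range from -8% to 16%.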

Compound 4, a percentage reported as inhibition, at one concentration (the size of the read-out at that concentration, not a potency): 3.97%
Compound 4: middle estimate off by 0 percentage points, on the high side; the measured number falls inside the stated range.
By their numbers in this assay, from the lowest: compounds 3, 2, 4 and 1 (each within the scatter of the next).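

At this aromatic carbon of the five-membered ring, 2-fluorophenyl leaves this assay within the scatter of all three earlier groups: a number 7.4 percentage points higher from compound 3 to compound 4 (within the scatter) and a number 3.8 percentage points higher from compound 2 to compound 4 (within the scatter) against the chains, and a number 2.3 percentage points lower from compound 1 to compound 4 (within the scatter) against 4-bromophenyl. So neither swapping one aromatic ring for another nor swapping a ring for a chain separates these compounds on this read-out at the single concentration tested. Nothing measured here offers a reason for these numbers. From the compounds shown here alone, whether an amine or a carboxylic acid at this carbon would give a number beyond the scatter remains open.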